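Adding a Methyl to Compound 2

The compounds below may be only part of what the source reports. "The series", "measured", "known", "first", "only" and "open" are said of these compounds alone.

Compound 1 `N/C(=N\NC(=S)N1CCCCCC1)c1ccccn1` and compound 3 `Cc1cccc(/C(N)=N/NC(=S)N2CCCCCC2)n1` share a core, and compound 3 carries a methyl in place of hydrogen on an aromatic carbon. In a functional assay on HeLa cells (Homo sapiens) for cytotoxicity, read by MTT assay, with a stated time of 72 h, tested at 10 uM (a higher number here means more inhibition of growth at the concentration tested, a lower number less inhibition of growth), compound 1 gives 67.4%, and compound 3 gives 71.7%; that change made a step of a number 4.3 percentage points higher from compound 1 to compound 3 (within the scatter). Compound 2 `N/C(=N\NC(=S)N1CCCCC1)c1ccccn1` gives 55.7% in this assay; the difference between the cores of compound 1 and compound 2 is not broken down here. Compound 4 `Cc1ccnc(/C(N)=N/NC(=S)N2CCCCC2)c1` has not been measured and differs from compound 2 by methyl in place of hydrogen on an aromatic carbon. This is the same kind of change as from compound 1 to compound 3, though the place is now opposite the ring nitrogen rather than next to the ring nitrogen. Because a number 4.3 percentage points higher from compound 1 to compound 3 (within the scatter) lay within the scatter, compound 4 is expected to make a step of only a number 4.3 percentage points higher from compound 2 to compound 4 (within the scatter). Compound 4 is therefore estimated at 60%, between 46% and 73%.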

Compound 4, percent growth inhibition at one concentration: 62.1%
Beside the measured number, compound 4's estimate is 2.1 percentage points below it; measured number inside the range.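

On the core of compound 2, the methyl opposite the ring nitrogen gives a number 6.4 percentage points higher from compound 2 to compound 4 (within the scatter) in this assay. Set beside the earlier step, the same change looks alike on the two cores: the same change on two cores in this assay, a number 4.3 percentage points higher (within the scatter) from compound 1 to compound 3 and a number 6.4 percentage points higher (within the scatter) from compound 2 to compound 4, 2.1 percentage points apart, within the scatter of two such steps. This does not show that the methyl truly raises growth inhibition on either core, as each step lies within the scatter, and the two methyls sit at different places on the ring, so core and place cannot be told apart.

As far as these compounds go, what an ethyl chain, an amine or a chlorine atom would do at this place remains open. So does the effect of a methyl opposite the ring nitrogen on the core of compound 1.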